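The compounds below may be only part of what the source reports. "The series", "measured", "known", "first", "only" and "open" are said of these compounds alone.

Compound 1 `C=CCONC(=O)CN1C(=O)S/C(=C\c2cccc(C(=O)N[C@@H](CC(C)C)C(=O)OC)c2)C1=O` in a functional assay on MRC5 cells (Homo sapiens) for inhibition, read by microscopy and resazurin assay, with a stated time of 72 h (on this read-out higher numbers stand for weaker inhibition and lower numbers for stronger inhibition), gives > 128000 nM, which is a limit of the assay rather than a number.
Compound 2 `COC(=O)[C@H](CC(C)C)NC(=O)c1cccc(/C=C2\SC(=O)N(CC(=O)NOCc3ccccc3)C2=O)c1` in this assay gives > 128000 nM, again a limit.
Compound 3 `C=CCONC(=O)Cn1cc(C(=O)NCC(=O)N[C@H](C(=O)O)C(C)C)c2ccccc21` in this assay gives > 128000 nM, also a limit.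

None of the three measured compounds inhibits the cells strongly enough for the assay to report a number, and this is summed up by the limit of > 128000 nM in this assay, at which 3 of the 3 values shown sit. From compound 1 to compound 2 the change is phenyl in place of vinyl on a saturated chain carbon bound to an oxygen on an unsaturated carbon. The resulting step that the two limits leave unreadable from compound 1 to compound 2 cannot be read, since both values are limits. Compound 4 `CC(C)[C@H](NC(=O)CNC(=O)c1cn(CC(=O)NOCc2ccccc2)c2ccccc12)C(=O)O` has not yet been measured; it arises from compound 3 by the same change, (phenyl in place of vinyl on a saturated chain carbon bound to an oxygen on an unsaturated carbon), at the same place. The difference between the core of compound 1 and the core of compound 3 is not broken down here. For the measured compounds named here, with the earlier pair unreadable, the only guide is that compound 3 sits at the limit because of the limit of > 128000 nM in this assay, at which 3 of the 3 values shown sit. The step of a number no higher from compound 3 to compound 4 (the limit leaves the size open) is therefore expected to be small. Compound 4 is estimated at 128000 nM, between 40000 nM and 400000 nM, most likely again reported only as a limit.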

Compound 4, half-maximal inhibitory concentration: > 128000 nM
Compound 4: only a limit was reported; the forecaster's own chance of this, stated with the estimate: 85%; the middle value lies on the limit itself.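

In this assay, compound 3 and compound 4 each give only a limit rather than a number, so the step between them cannot be read, just as for compound 1 and compound 2. Still open is whether phenyl in place of vinyl changes inhibition of these cells at all, and what would bring any value into the measurable range, with every result resting on one figure: the limit of > 128000 nM in this assay, at which 4 of the 4 values shown sit.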